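Amide nitrogen substituent variation in a cyanoacrylamide series

The compounds below may be only part of what the source reports. "The series", "measured", "known", "first", "only" and "open" are said of these compounds alone.

Measured so far:
compound 1, `CC(=O)OC[C@H](NC(=O)/C(C#N)=C/c1cccc(Br)n1)c1ccccc1`: 2600 nM
compound 2, `N#C/C(=C\c1ccc(-c2cccc([N+](=O)[O-])c2)o1)C(=O)NC(c1ccccc1)C1CC1`: > 10000 nM

Both compounds were tested in a functional assay on MM1 cells (Homo sapiens) for antiproliferative activity, read by MTT assay, with a stated time of 72 h; a lower number here means a stronger inhibitor, a higher number a weaker inhibitor. Compound 1 gives 2600 nM and so sits at a number rather than a bound. For compound 2 the result is a limit of the assay, > 10000 nM, not a number, and it therefore stands at the weak edge of what this assay reports; see (the limit of > 10000 nM in this assay, at which 1 of the 2 values shown sits). Between compound 1 and compound 2 there is no single-point step, so the two values can only be set side by side.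

Compound 3, `Cc1ccc(CNC(=O)/C(C#N)=C/c2ccc(-c3cccc([N+](=O)[O-])c3)o2)cc1`, has not been measured. It differs from compound 2 in one place: 4-methylbenzyl in place of cyclopropyl(phenyl)methyl on an amide-type nitrogen. The core of compound 2 is kept unchanged.

Within the data shown here, since compound 2 already sits at the limit, no measured step gives a size for this kind of change. The expected step from compound 2 to compound 3 is a number no higher from compound 2 to compound 3 (the limit leaves the size open), that is, none beyond the scatter in either direction. Compound 3 is therefore expected to give 10000 nM, in the range 3000 nM to 30000 nM, with a real chance that this assay again returns only a limit.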

Compound 3, half-maximal inhibitory concentration: > 10000 nM
Compound 3 gave a limit, no number; the forecaster's own chance of this, stated with the estimate: 55%; the middle value lies on the limit itself.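

In this assay compound 3 gives > 10000 nM, a limit of the assay and not a number. Among these compounds, compound 2 also stands at a limit, so no step between compound 2 and compound 3 can be read. Still open, going by these compounds, is how 4-methylbenzyl and cyclopropyl(phenyl)methyl on the amide-type nitrogen compare in this assay on this core.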